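Removing both methoxy groups from the aryl ring of compound 1

This account rests on a few compounds, and the source may have more. Where it says the series, first, only, none or still open, it means among the compounds named here.

Compound 1 `COc1ccc(-c2nnc(SCC(=O)c3ccccc3)n2-c2ccccc2)cc1OC` gives 56% in a functional assay on the whole organism (strain albino) for inhibition, with Rattus norvegicus as the target, read by paw edema, with a stated time of 1 h, at a dose of 0.28 mmol/kg by the oral route; a lower number here means less inhibition, a higher number more inhibition at the dose given (going by the name of the read-out). Among the three measured compounds it stands second highest: compound 2 `C=CCn1c(SCC(=O)c2ccccc2)nnc1-c1ccc(OC)c(OC)c1` gives 61% and compound 3 `C=CCn1c(SCC(=O)c2ccccc2)nnc1-c1ccc(OC)cc1` gives 49%, with a number 5 percentage points higher from compound 1 to compound 2 (within the scatter) and the two remaining values within the scatter of each other. Compound 4 `O=C(CSc1nnc(-c2ccccc2)n1-c1ccccc1)c1ccccc1` differs from compound 1 in one place: phenyl in place of 3,4-dimethoxyphenyl on an aromatic carbon. Among the compounds with values here, the closest measured step is a number 12 percentage points lower from compound 2 to compound 3 (beyond the scatter), where only one methoxy left the ring. Here two methoxy groups leave at once, so a larger drop is expected than that single-methoxy step, though the series holds no direct test of removing both. The expected step is a number 16 percentage points lower from compound 1 to compound 4 (beyond the scatter), giving compound 4 an estimated 40% with a range of 28% to 52%.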

Compound 4, a percentage reported as inhibition, in the whole organism at one dose (the size of the read-out at that dose, not a potency): 53%
For compound 4 the middle estimate is 13 percentage points below the measured one; the whole stated range lies below it.
By their numbers in this assay, from the lowest: compounds 3, 4, 1 and 2 (each within the scatter of the next, the first and the last beyond it).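

In this assay the 3,4-dimethoxyphenyl gives way to phenyl on this aromatic carbon with a number 3 percentage points lower from compound 1 to compound 4 (within the scatter), so with phenyl on the ring nitrogen the two methoxy groups are not needed to hold the number. Losing one methoxy group with allyl on the ring nitrogen gives a number 12 percentage points lower from compound 2 to compound 3 (beyond the scatter), so methoxy loss does not read the same in the two settings. No data at hand bear on the reason for this.

Open, as far as these compounds go, is whether an amine or a carboxylic acid on this phenyl would move the number. Also open, from the compounds shown here alone, is whether phenyl here, paired with allyl on the ring nitrogen, would read like compound 3 or compound 4.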